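Sulfonamide swap on two weakly cytotoxic chromone hybrids

The compounds below may be only part of what the source reports. "The series", "measured", "known", "first", "only" and "open" are said of these compounds alone.

Compound 1 `O=C1/C(=C/c2coc3ccccc3c2=O)N=C(c2ccccc2)N1c1ccc(S(=O)(=O)Nc2nccs2)cc1` gives 88400 nM in a functional assay on A549 cells (Homo sapiens) for cytotoxicity, read by sulforhodamine B assay, with a stated time of 72 h; a lower number here means a stronger inhibitor, a higher number a weaker inhibitor. Compound 3 `Cc1cc(C)nc(NS(=O)(=O)c2ccc(N3C(=O)/C(=C/c4coc5ccccc5c4=O)N=C3c3ccccc3)cc2)n1` differs from it by 4,6-dimethylpyrimidin-2-yl in place of 1,3-thiazol-2-yl on a sulfonamide nitrogen, and in this assay compound 3 gives 63200 nM; the step of a 1.4-fold lower number from compound 1 to compound 3 (0.15 log units; within the scatter) is small. Compound 2 `O=C1N=C(Nc2ccc(S(=O)(=O)Nc3nccs3)cc2)S/C1=C/c1coc2ccccc2c1=O` is built on a different core, and the difference between the two cores is not broken down here. In this assay compound 2 gives > 100000 nM, which is a limit of the assay rather than a number, as the limit of > 100000 nM in this assay, at which 1 of the 3 values shown sits, records. Compound 4 `Cc1cc(C)nc(NS(=O)(=O)c2ccc(NC3=NC(=O)/C(=C\c4coc5ccccc5c4=O)S3)cc2)n1` differs from compound 2 by the same change, (4,6-dimethylpyrimidin-2-yl in place of 1,3-thiazol-2-yl on a sulfonamide nitrogen). Beside the measured step, the step is expected to be about a step that the limit leaves unreadable from compound 2 to compound 4, resting on a 1.4-fold lower number from compound 1 to compound 3 (0.15 log units; within the scatter). Compound 4 is therefore estimated at 110000 nM, between 50000 nM and 300000 nM.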

Compound 4, half-maximal inhibitory concentration: > 100000 nM
Compound 4 ended at the assay's limit; the forecaster's own chance of this, stated with the estimate: 60%; the middle value lies beyond the limit too.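

No step can be read from compound 2 to compound 4, because both stop at the same limit of the assay rather than at a number: the limit of > 100000 nM in this assay, at which 2 of the 4 values shown sit.

The compounds shown leave open whether 4,6-dimethylpyrimidin-2-yl in place of 1,3-thiazol-2-yl changes anything on the core of compound 2 in this assay.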